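The source may report more compounds than this note shows. Statements on the series, on what has been measured and on what is new or still open speak of the compounds shown alone.

Series in a functional assay on CCRF-CEM cells (Homo sapiens) for cytotoxicity; a lower number here means a stronger inhibitor, a higher number a weaker inhibitor:
- compound 1 `Cc1ccc(C(=O)/C=C/c2cc(O)nc(O)n2)cc1`: 1800 nM
- compound 2 `Cc1ccc(C(=O)/C=C/c2nc(O)nc(O)c2Br)cc1`: 2600 nM
- compound 3 `Cc1ccc(C(=O)/C=C/c2nc(O)nc(O)c2I)cc1`: not yet measured

Among the measured compounds shown here, compound 2, at 2600 nM, cannot be separated from compound 1, the only other measured compound, as the two values lie within the scatter of each other. The open change is iodo in place of bromo on an aromatic carbon. For the measured compounds named here, one measured step bears on it, bromo in place of hydrogen on an aromatic carbon: a 1.4-fold higher number from compound 1 to compound 2 (0.16 log units; within the scatter), which stays within the scatter. This single small step is thin evidence, but it gives no reason to expect a large shift in this assay and points to no direction. The expected change is a 1.0-fold lower number from compound 2 to compound 3 (0.02 log units; within the scatter), which means no expected step beyond the scatter. Compound 3 is estimated at 2500 nM, with an expected range of 1100 nM to 5500 nM.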

Compound 3, half-maximal inhibitory concentration: 1400 nM
For compound 3 the middle estimate is 1.8-fold (0.25 log units) above the measured one; measured number inside the range.
By their numbers in this assay, from the lowest: compounds 3, 1 and 2 (each within the scatter of the next).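

In this assay this ring carbon, ortho to a large group, now carries hydrogen, bromo or iodo, and swapping the halogen gives a 1.9-fold lower number from compound 2 to compound 3 (0.27 log units; within the scatter), while iodo in place of hydrogen gives a 1.3-fold lower number from compound 1 to compound 3 (0.11 log units; within the scatter). Both steps stay within the scatter, so the three compounds cannot be ordered, and neither halogen separates from hydrogen at this position in this series. No measured evidence is available to explain these results.

As far as these compounds go, whether a non-halogen substituent at this position, such as an amine, a methoxy group or a carboxylic acid, would move the value beyond the scatter remains open. Also open, from the compounds shown here alone, is whether this flat reading would hold if the methyl group of the shared core gave way to a longer chain.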